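The source may report more compounds than this note shows. Statements on the series, on what has been measured and on what is new or still open speak of the compounds shown alone.

For the measured compounds named here, compound 2 `N#CC1=C(N2C(=O)CCC2=O)N(c2ccc(S(N)(=O)=O)cc2)C2=C(C(=O)CCC2)C1c1ccc(Cl)cc1Cl` is the one compound of the pair with a definite number in a functional assay on Ehrlich cells (Mus musculus) for cytotoxicity, read by trypan blue exclusion, with a stated time of 2 h; on this read-out lower numbers stand for stronger inhibition and higher numbers for weaker inhibition: compound 2 gives 25 ug/mL. Compound 1 `C=CCNC(=S)NC1=C(C#N)C(c2ccc(Cl)cc2Cl)C2=C(CCCC2=O)N1c1ccc(S(N)(=O)=O)cc1` reaches only (the limit of > 100 ug/mL in this assay, at which 1 of the 2 values shown sits), so for compound 1 the entry > 100 ug/mL is a limit of this assay rather than a number. Going by the values given here, the one measured step, an at least 4.0-fold lower number from compound 1 to compound 2 (0.60 log units; beyond the scatter), swaps one seven-atom group for another at the same ring carbon. Compound 3 `N#CC1=C(NS(=O)(=O)c2ccc(Br)cc2)N(c2ccc(S(N)(=O)=O)cc2)C2=C(C(=O)CCC2)C1c1ccc(Cl)cc1Cl` changes that same position again: ((4-bromophenyl)sulfonyl)amino in place of 2,5-dioxopyrrolidin-1-yl on a double-bonded ring carbon. The measured step bears on it only as far as it shows that replacing the group on that carbon can move the read-out at least modestly; it gives no direction for a ((4-bromophenyl)sulfonyl)amino group. With no closer comparison, the expectation is a step about the scatter, a 1.2-fold higher number from compound 2 to compound 3 (0.08 log units; within the scatter), so compound 3 is estimated at 30 ug/mL, expected within 10 ug/mL to 100 ug/mL in this assay.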

Compound 3, half-maximal inhibitory concentration: 5.5 ug/mL
Compound 3: the middle estimate sits 5.5-fold (0.74 log units) above what was measured; the whole stated range lies above it.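

In this assay, the group on this double-bonded ring carbon can lower the number further than the 2,5-dioxopyrrolidin-1-yl group did, with ((4-bromophenyl)sulfonyl)amino giving a 4.5-fold lower number from compound 2 to compound 3 (0.66 log units; beyond the scatter). Across the three groups shown at this carbon, the widest step is an at least 18-fold lower number from compound 1 to compound 3 (1.25 log units; beyond the scatter). For compound 1, the entry is a limit and not a number, so that step has no fixed size: the limit of > 100 ug/mL in this assay, at which 1 of the 3 values shown sits.

The entering group brings a sulfonyl, an aromatic ring, a bromine and a hydrogen-bond donor all at once, and the compounds shown do not separate these features. A phenylsulfonylamino group without the bromine, a methylsulfonylamino group or a free amine at this carbon would show which part goes with the lower number.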